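The compounds below may be only part of what the source reports. "The series", "measured", "known", "first", "only" and "open" are said of these compounds alone.

This small set of compounds shares one core and varies the group attached to a nitrogen on an aromatic ring. For the measured compounds named here, compound 1 `C[C@@H](CO)Nc1nc(C(=O)NCc2ccc(F)cc2)c(O)c2ncccc12` is the first member. In a functional assay on HCT-116 cells (Homo sapiens) for cytotoxicity, read by MTT assay, with a stated time of 72 h (a lower number here means a stronger inhibitor, a higher number a weaker inhibitor), compound 1 gives "not determined" (no result reported). Compound 2 `C[C@@H](Nc1c(C(=O)NCc2ccc(F)cc2)nc(Br)c2cccnc12)c1ccccc1` carries a (1-phenylethyl)amino group in that place. In this assay compound 2 gives > 20000 nM, which is a limit of the assay rather than a number. Compound 3 `CC(C)(C)OC(=O)N1CCN(c2c(C(=O)NCc3ccc(F)cc3)nc(Br)c3cccnc23)CC1` is the third member. In this assay compound 3 gives > 10000 nM, again a limit rather than a number.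

Compound 2 therefore stands only at a limit. Going by the values given here, of the other two entries, one sits at the limit of > 10000 nM in this assay, at which 1 of the 3 values shown sits, and one carries no number at all, so no measured step between any two compounds can be drawn.

Compound 4 `CNc1c(C(=O)NCc2ccc(F)cc2)nc(Br)c2cccnc12` has not yet been measured in this assay. It differs from compound 2 by methyl in place of 1-phenylethyl on a nitrogen on an aromatic ring. Because compound 2 sits at the limit of > 20000 nM in this assay, at which 1 of the 3 values shown sits, and compound 3 sits at a limit as well, the expected step of a number no higher from compound 2 to compound 4 (the limit leaves the size open) is none beyond the scatter, with the result most likely reported again only as a limit. Compound 4 is expected to give about 20000 nM, within a range from 5000 nM to 60000 nM.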

Compound 4, half-maximal inhibitory concentration: > 20000 nM
Compound 4 gave a limit, no number; the forecaster's own chance of this, stated with the estimate: 70%; the middle value lies on the limit itself.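

Compound 2 and compound 4 both stand only at a limit of the assay, so the size of any step between them cannot be read: the limit of > 20000 nM in this assay, at which 2 of the 4 values shown sit.

The compounds shown leave open what number any of them would reach in this assay, and so whether methyl or 1-phenylethyl on that nitrogen makes any difference there.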